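Cyclohexyl Amide in a Stilbene-Pyridine Series

The source may hold more compounds than are shown below. What is called first, only, known or untested is meant among the compounds shown, and "the series" means these compounds.

Compound 3 `O=C(Nc1ccc(Cl)cc1)c1cc(Oc2ccc(/C=C/c3ccncc3)cc2)ccn1` carries a 4-chlorophenyl on its amide-type nitrogen. In a functional assay on HepG2 cells (Homo sapiens) for antiproliferative activity, read by CCK-8 assay, with a stated time of 48 h (a lower number here means a stronger inhibitor, a higher number a weaker inhibitor), compound 3 gives 56200 nM, the highest of the three numbers shown, though the step of a 1.8-fold higher number from compound 1 to compound 3 (0.25 log units; within the scatter) stays within the scatter. Compound 1 `O=C(Nc1ccc(Cl)cc1)c1cc(Oc2ccc(/C=C/c3ccccn3)cc2)ccn1` gives 31300 nM in this assay, and compound 2 `O=C(NC1CC1)c1cc(Oc2ccc(/C=C/c3ccccn3)cc2)ccn1` gives 31000 nM. Compound 4 `O=C(NC1CCCCC1)c1cc(Oc2ccc(/C=C/c3ccncc3)cc2)ccn1` differs from compound 3 by cyclohexyl in place of 4-chlorophenyl on an amide-type nitrogen. Among the measured compounds shown here, the one step that bears on this is a 1.0-fold lower number from compound 1 to compound 2 (0.00 log units; within the scatter), which also replaced the 4-chlorophenyl on the amide-type nitrogen with a non-aromatic ring of carbon only and stayed within the scatter. No step beyond the scatter is therefore expected for compound 4 in this assay: a 1.0-fold lower number from compound 3 to compound 4 (0.00 log units; within the scatter). Compound 4 is estimated at 56000 nM, within 25000 nM to 130000 nM.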

Compound 4, half-maximal inhibitory concentration: 22400 nM
Compound 4: middle estimate off by 2.5-fold (0.40 log units), on the high side; measured number below the stated range.
By their numbers in this assay, from the lowest: compounds 4, 2, 1 and 3 (each within the scatter of the next, the first and the last beyond it).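

The amide-type nitrogen is not a silent position: the step of a 2.5-fold lower number from compound 3 to compound 4 (0.40 log units; beyond the scatter) in this assay shows that cyclohexyl in place of 4-chlorophenyl can lower the number beyond the scatter, whereas the step of a 1.0-fold lower number from compound 1 to compound 2 (0.00 log units; within the scatter) did not. An aromatic ring on this nitrogen is therefore not needed for activity at this level. Nothing shown here explains the step. Still open, from the compounds shown here alone, is whether cyclohexyl would give a similar step with the pyridin-2-yl group of compound 1. Also open, going by these compounds, is how a piperidine ring or a straight hexyl chain would read on this nitrogen.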